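Methyl in place of nitro on a biaryl ester

This account rests on a few compounds, and the source may have more. Where it says the series, first, only, none or still open, it means among the compounds named here.

Of the compounds shown here, three sharing one core have so far been measured in an assay on COS-7 cells for inhibition of patatin-like phospholipase domain-containing protein 2 (Mus musculus), tested at 200 uM; on this read-out lower numbers stand for less inhibition and higher numbers for more inhibition at the one concentration tested (going by the name of the read-out). Compound 1 `CCOC(=O)c1cccc(-c2ccc(OC)cc2)c1` gives 77%. Compound 2 `CCOC(=O)c1cccc(-c2ccc(N(C)C)cc2)c1` gives 87%, and the step of a number 10 percentage points higher from compound 1 to compound 2 (within the scatter) stays within the scatter. Compound 3 `CCOC(=O)c1cccc(-c2ccc([N+](=O)[O-])cc2)c1` gives 63%, the lowest of the three numbers; its nearest neighbour is compound 1 and its furthest is compound 2. The two measured steps that lead to compound 3 both point the same way: a number 14 percentage points lower from compound 1 to compound 3 (beyond the scatter) and a number 24 percentage points lower from compound 2 to compound 3 (beyond the scatter).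

Compound 4 `CCOC(=O)c1cccc(-c2ccc(C)cc2)c1` has not yet been measured. Its difference from compound 3 is methyl in place of nitro on an aromatic carbon. Both recorded steps into compound 3 replaced the group on this aromatic carbon with nitro and brought the number down by a modest amount, so taking nitro away again would be expected to move the number back up. Methyl has not been measured at this position, so the size of the return is uncertain; a rise of roughly the size seen in those two steps seems the most reasonable expectation. In this assay compound 4 is therefore expected to give 74%, within a range from 58% to 88%, which means an expected step of a number 11 percentage points higher from compound 3 to compound 4 (beyond the scatter).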

Compound 4, a percentage reported as inhibition, at one concentration (the size of the read-out at that concentration, not a potency): 63%
Compound 4: middle estimate off by 11 percentage points, on the high side; measured number inside the range.
By their numbers in this assay, from the lowest: compounds 3 and 4 (each within the scatter of the next); then compounds 1 and 2 (each within the scatter of the next).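

Nitro and methyl have little in common, yet in this assay the swap gives no change at the digits printed from compound 3 to compound 4 (within the scatter), so the lower level of compound 3 is not tied to nitro: a smaller group with no hydrogen-bond acceptors sits at that same level. Methyl also falls short of the other two groups at this aromatic carbon, with a number 24 percentage points lower from compound 2 to compound 4 (beyond the scatter) and a number 14 percentage points lower from compound 1 to compound 4 (beyond the scatter), so the four compounds now form two levels, with methoxy and dimethylamino in the upper one and nitro and methyl in the lower. No measurement is available that would explain why these groups divide this way.

The compounds shown leave open where a primary amine, a hydroxyl group or a chlorine atom on this carbon would fall, and so which feature, if any, the two upper groups share that nitro and methyl lack. They also leave open whether the two levels would hold at other concentrations, or if a carboxylic acid replaced the ethyl ester of the shared core.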